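Trifluoromethyl for Chloro in a Cytotoxicity Test

The source may report more compounds than this note shows. Statements on the series, on what has been measured and on what is new or still open speak of the compounds shown alone.

In an ADME assay on MT4 cells (Homo sapiens) for cytotoxicity, read by MTT assay, with a stated time of 96 h (a higher number here means that more compound is tolerated, a lower number that less compound is tolerated), compound 1 (`Clc1cccc(/N=N/N2CCCC2)c1`) gives > 100000 nM as a limit of the assay, not a number. Compound 2 (`CN(C)CCCN(/N=N/c1cc(F)ccc1F)c1ccccc1`) gives 13000 nM as a measured number. Compound 3 (`FC(F)(F)c1cccc(/N=N/N2CCCC2)c1`) keeps the core of compound 1 but carries trifluoromethyl in place of chloro on an aromatic carbon. Within the data shown here, no measured pair shows what this change does, so in this assay only a small expected move toward less compound being tolerated is assumed (an at least 1.2-fold lower number from compound 1 to compound 3 (0.09 log units; that floor lies within the scatter)), and it may not exceed the usual scatter. For compound 3 the estimate is 80000 nM with an expected range from 30000 nM to 150000 nM around it.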

Compound 3, half-maximal cytotoxic concentration: > 100000 nM
Compound 3: a limit, no number; the forecaster's own chance of this, stated with the estimate: 55%; middle value at least 1.2-fold (0.09 log units) from the limit.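

Among these compounds, compound 1 and compound 3 each end at a limit of the assay, not a number, so no step between them can be read: the limit of > 100000 nM in this assay, at which 2 of the 3 values shown sit.

In this assay the compounds shown leave open how far trifluoromethyl in place of chloro on an aromatic carbon shifts the tolerated concentration.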